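Fluoro to chloro step carried onto the methoxy analogue

A few compounds are considered here, and "the series" means these few. Any claim that something is new, unique, unknown or untested is made for them only; others in the source may bear on it.

Compound 1 `Cc1ccc(-c2nn(-c3ccccc3)cc2C(=O)NOCc2ccccc2F)cc1` and compound 2 `Cc1ccc(-c2nn(-c3ccccc3)cc2C(=O)NOCc2ccccc2Cl)cc1` differ by chloro in place of fluoro on an aromatic carbon. In an ADME assay on HEK-293T cells (Homo sapiens) for antiproliferative activity, read by MTT assay, with a stated time of 48 h, in the presence of a further agent that is not named here (a lower number here means that less compound is tolerated, a higher number that more compound is tolerated), compound 1 gives 20600 nM and compound 2 gives 38700 nM, a step of a 1.9-fold higher number from compound 1 to compound 2 (0.27 log units; within the scatter). The core of compound 3 `COc1ccc(-c2nn(-c3ccccc3)cc2C(=O)NOCc2ccccc2F)cc1` differs by methoxy in place of methyl on an aromatic carbon, and in this assay compound 3 gives 24600 nM, a step of a 1.2-fold higher number from compound 1 to compound 3 (0.08 log units; within the scatter). Compound 4 `COc1ccc(-c2nn(-c3ccccc3)cc2C(=O)NOCc2ccccc2Cl)cc1` is not yet measured; it differs from compound 3 by chloro in place of fluoro on an aromatic carbon, the same change as made earlier, since the surroundings of the place read alike. The step from compound 3 to compound 4 in this assay is expected at a 1.7-fold higher number from compound 3 to compound 4 (0.23 log units; within the scatter). This expectation rests on the earlier step of a 1.9-fold higher number from compound 1 to compound 2 (0.27 log units; within the scatter) and on compound 3 with 24600 nM standing close to compound 1. Compound 4 is estimated at 42000 nM, between 22000 nM and 80000 nM, in this assay.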

Compound 4, half-maximal cytotoxic concentration: 586000 nM
Compound 4: middle estimate off by 14-fold (1.14 log units), on the low side; measured number outside the range, above it.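

In this assay, chloro in place of fluoro on the methoxy core gives a 24-fold higher number from compound 3 to compound 4 (1.38 log units; beyond the scatter), so the size of this step does not carry over from the methyl core: the same change on two cores in this assay, a 1.9-fold higher number (0.27 log units; within the scatter) from compound 1 to compound 2 and a 24-fold higher number (1.38 log units; beyond the scatter) from compound 3 to compound 4, 13-fold (1.10 log units) apart, beyond the scatter of two such steps

Read the other way, with the 2-chlorobenzyl group held fixed, methoxy in place of methyl gives a 15-fold higher number from compound 2 to compound 4 (1.18 log units; beyond the scatter), so the two changes do not add up independently here: the same change on two cores in this assay, a 1.2-fold higher number (0.08 log units; within the scatter) from compound 1 to compound 3 and a 15-fold higher number (1.18 log units; beyond the scatter) from compound 2 to compound 4, 13-fold (1.10 log units) apart, beyond the scatter of two such steps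

Within the data shown here, both large steps rest on the single value of compound 4, and they show neither a cause nor whether such a step would recur on another core.

Open, from the compounds shown here alone, is whether a large step also appears with bromo in place of chloro on the same aromatic carbon, or with an amine or a carboxylic acid in place of methoxy.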